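The source may hold more compounds than are shown below. What is called first, only, known or untested is meant among the compounds shown, and "the series" means these compounds.

Compound 3 `COc1ccc2nc(C)cc(OCC(=O)Nc3ccc(Cl)cc3)c2c1` gives 9000 nM in a physicochemical assay for solubility, in phosphate buffer, measured as kinetic solubility, with a stated time of 1 h, at pH 7.4; a lower number here means a less soluble compound, a higher number a more soluble compound. Compound 2 `COc1ccc2nc(C)cc(OCC(=O)Nc3ccc(Cl)c(OC)c3)c2c1` gives 13000 nM, within the scatter of compound 3, and compound 1 `COc1ccc2nc(C)cc(OCC(=O)Nc3c(C)cccc3C)c2c1` gives 112000 nM, clearly above both. Compound 4 `COc1ccc2nc(C)cc(OCC(=O)Nc3cc(C)nc(C)n3)c2c1` differs from compound 3 by 2,6-dimethylpyrimidin-4-yl in place of 4-chlorophenyl on an amide-type nitrogen. Exchanges of the group on the amide-type nitrogen have moved this assay before: an 8.6-fold lower number from compound 1 to compound 2 (0.94 log units; beyond the scatter) and a 12-fold lower number from compound 1 to compound 3 (1.09 log units; beyond the scatter), both beyond the scatter, whereas a 1.4-fold lower number from compound 2 to compound 3 (0.16 log units; within the scatter). The entering group carries two hydrogen-bond acceptors where the leaving group had none, and a step of comparable size in the upward direction is therefore expected. Compound 4 is expected at 36000 nM, with a range from 12000 nM to 120000 nM. The expected step is a 4.0-fold higher number from compound 3 to compound 4 (0.60 log units; beyond the scatter).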

Compound 4, solubility: 5000 nM
Compound 4: the middle estimate sits 7.2-fold (0.86 log units) above what was measured; measured number below the stated range.
By their numbers in this assay, from the lowest: compounds 4, 3 and 2 (each within the scatter of the next, the first and the last beyond it); then compound 1.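

On the amide-type nitrogen, 2,6-dimethylpyrimidin-4-yl with its 2 hydrogen-bond acceptors does not separate from 4-chlorophenyl in this assay: a 1.8-fold lower number from compound 3 to compound 4 (0.26 log units; within the scatter). For the compounds shown here, the other two exchanges give a 2.6-fold lower number from compound 2 to compound 4 (0.41 log units; beyond the scatter) and a 22-fold lower number from compound 1 to compound 4 (1.35 log units; beyond the scatter), so 2,6-dimethylphenyl remains the one group here beyond the scatter of all the others. No measurement at hand bears on the cause of this result.

Open, on these data alone, is where a group carrying an amine or a carboxylic acid on the amide-type nitrogen would fall in this assay. Also open, as far as these compounds go, is whether any group other than 2,6-dimethylphenyl reaches the level of compound 1.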